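The compounds below may be only part of what the source reports. "The series", "measured", "known", "first", "only" and "open" are said of these compounds alone.

Compound 1 `O=S(=O)(Nc1ccc2ccccc2c1)c1ccc2nc(-c3ccccc3)c(-c3ccccc3)nc2c1` is a sulfonamide whose nitrogen carries a naphthalen-2-yl group. In an ADME assay on the whole organism for pharmacokinetics, with Homo sapiens as the target (a lower number here means that a smaller share of the oral dose reaches the circulation, a higher number that a larger share of the oral dose reaches the circulation), compound 1 gives 100%. For the measured compounds named here, compound 2 `Cc1ccnc(NS(=O)(=O)c2ccc3nc(-c4ccccc4)c(-c4ccccc4)nc3c2)c1` carries a 4-methylpyridin-2-yl group in its place, and in this assay compound 2 gives 100%, so the step of no change at the digits printed from compound 1 to compound 2 (within the scatter) stays within the scatter; compound 2 therefore stands level with compound 1 on the single value shown for each. Compound 3 `O=[N+]([O-])c1cccc(NS(=O)(=O)c2ccc3nc(-c4ccccc4)c(-c4ccccc4)nc3c2)c1`, not yet measured, differs from compound 2 in one place: 3-nitrophenyl in place of 4-methylpyridin-2-yl on a sulfonamide nitrogen. Going by the values given here, the only measured step, no change at the digits printed from compound 1 to compound 2 (within the scatter), exchanged one aromatic group on that nitrogen for another without moving the read-out beyond the scatter, and both measured compounds already sit at the upper end of what this assay reports. On that basis the step of no change at the digits printed from compound 2 to compound 3 (within the scatter) is expected to stay within the scatter. For compound 3 the expected value in this assay is 100%, with a range from 85% to 100%.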

Compound 3, oral bioavailability: 85.6%
Estimate against measurement, compound 3: 14.4 percentage points above, and the stated range covers the measured number.
By their numbers in this assay, from the lowest: compound 3; then compounds 1 and 2 (each within the scatter of the next).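

In this assay, the group on the sulfonamide nitrogen turns out to matter: 3-nitrophenyl in place of 4-methylpyridin-2-yl gives a number 14.4 percentage points lower from compound 2 to compound 3 (beyond the scatter), and 3-nitrophenyl in place of naphthalen-2-yl gives a number 14.4 percentage points lower from compound 1 to compound 3 (beyond the scatter). Compounds 1 and 2 alone made this position look indifferent to which aromatic group it carries, whereas these two steps show that at least one such group separates from the others beyond the scatter. Nothing available explains this difference.

The compounds shown leave open whether the nitro group itself goes with the lower number or the carbon-only ring that carries it does. A plain phenyl group on the same nitrogen, or a phenyl ring bearing an amine or a carboxylic acid instead of the nitro group, would help separate these two readings.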